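A few compounds are considered here, and "the series" means these few. Any claim that something is new, unique, unknown or untested is made for them only; others in the source may bear on it.

Compound 1 `C=CC1=C(C(=O)NCc2ccccc2)C(c2ccc(OC)cc2)OC1`; compound 2 `C=CC1=C(C(=O)O)C(c2ccc(F)cc2)OC1`; compound 3 `C=CC1=C(C(=O)O)C(c2ccc(OC)cc2)OC1`.

In a functional assay on HeLa cells (Homo sapiens) for cytotoxicity, read by MTT assay, with a stated time of 24 h (a higher number here means a weaker inhibitor, a lower number a stronger inhibitor), compound 2 gives 67400 nM, a weak result. Compound 1 gives > 100000 nM, which is a limit of the assay rather than a number. Going by the values given here, compound 2 thus holds the only number, and the limit of > 100000 nM in this assay, at which 1 of the 2 values shown sits, shows where the other value sits. Compound 3 differs from compound 2 by methoxy in place of fluoro on an aromatic carbon. Among the compounds with values here, no measured pair shows this change alone, so the step from compound 2 to compound 3 is expected to be small, toward weaker inhibition, a 1.3-fold higher number from compound 2 to compound 3 (0.13 log units; within the scatter). Compound 3 is estimated at 90000 nM, within 40000 nM to 200000 nM.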

Compound 3, half-maximal inhibitory concentration: 44300 nM
Compound 3: the middle estimate sits 2.0-fold (0.31 log units) above what was measured; low and high end bracket the measured number.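

Methoxy in place of fluoro, para to a large group, gives only a 1.5-fold lower number from compound 2 to compound 3 (0.18 log units; within the scatter) in this assay, so these two compounds do not separate the two groups. Hydroxy in place of benzylamino on the carbonyl carbon gives a clearer change, an at least 2.2-fold lower number from compound 1 to compound 3 (0.35 log units; beyond the scatter). The value of compound 1 is a limit and not a number: the limit of > 100000 nM in this assay, at which 1 of the 3 values shown sits.

From the compounds shown here alone, it remains open whether an amine or a longer chain in place of methoxy would move the result beyond the scatter. Going by these compounds, it is also open whether a smaller methylamino group on the carbonyl carbon would behave like benzylamino.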